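Swapping the thiophene for a fluorophenyl on the quinolinone core

The source may report more compounds than this note shows. Statements on the series, on what has been measured and on what is new or still open speak of the compounds shown alone.

Compound 1: `O=[N+]([O-])c1cc2c(OCCC3CCCCN3)c(-c3cccs3)c(O)nc2cc1Cl` — 220 nM
Compound 2: `O=[N+]([O-])c1cc2c(OCCC3CCCCN3)c(-c3cc(C(F)(F)F)cc(C(F)(F)F)c3)c(O)nc2cc1Cl` — 71 nM

Of the compounds shown here, two have been measured in a functional assay on cells (Pituitary gland cell) for antagonist activity at Gonadotropin-releasing hormone receptor (Rattus norvegicus); a higher number here means a weaker inhibitor, a lower number a stronger inhibitor. Compound 1, with a thiophen-2-yl on the shared core, gives 220 nM, the highest of the two numbers. Compound 2, which carries a bis(trifluoromethyl)phenyl in that same position, gives 71 nM, a lower number, and the gap between compound 1 and compound 2 lies beyond the usual scatter.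

The next compound, compound 3 `O=[N+]([O-])c1cc2c(OCCC3CCCCN3)c(-c3cccc(F)c3)c(O)nc2cc1Cl`, is not yet measured. It differs from compound 1 in one place: 3-fluorophenyl in place of thiophen-2-yl on an aromatic carbon. For the measured compounds named here, no direct step from a measured pair covers this exact exchange, so the expectation rests on what compound 1 and compound 2 show. Going by the values given here, the only phenyl-bearing compound, compound 2, gives the lower number 71 nM, while the thiophene-bearing compound 1 gives 220 nM. Compound 3 is therefore expected to move toward a lower number, though by a smaller step than compound 2 shows; the estimated step is a 1.7-fold lower number from compound 1 to compound 3 (0.23 log units; within the scatter). For compound 3 the expected value is 130 nM, estimated to lie between 50 nM and 330 nM.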

Compound 3, half-maximal inhibitory concentration: 53 nM
The estimate for compound 3 lay 2.5-fold (0.39 log units) above the measured number, and the stated range covers the measured number.
By their numbers in this assay, from the lowest: compounds 3 and 2 (each within the scatter of the next); then compound 1.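

In this assay, putting 3-fluorophenyl in place of thiophen-2-yl on this aromatic carbon gives a 4.2-fold lower number from compound 1 to compound 3 (0.62 log units; beyond the scatter) and so shows that this one exchange, on its own, moves the number beyond the scatter. It also shows that the position accepts more than one kind of phenyl: compound 2 at 71 nM with its two trifluoromethyl groups and compound 3 at 53 nM with its one fluorine lie within the scatter of each other, and both stand below compound 1, so a heavily substituted ring and a lightly substituted one cannot be told apart here. Nothing among the available data explains why this exchange lowers the number.

The compounds shown leave open how much of the step belongs to the six-membered ring and how much to the fluorine, as plain phenyl does not stand among them. They also leave open whether 4-fluorophenyl, a pyridine ring or a phenyl carrying an amine would keep a number in the same range in this position.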